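Compound 3: A Mirror Change at One Ring Carbon

The source may hold more compounds than are shown below. What is called first, only, known or untested is meant among the compounds shown, and "the series" means these compounds.

- compound 1 `CCCNC(=O)[C@@H]1C[C@H]2CCC[C@@H](C1)[C@@H]2NC(=O)c1cc2sc(-c3ccccc3)nc2n1Cc1ccc(OC)cc1`: > 100000 nM
- compound 2 `CCCNC(=O)[C@@H]1[C@@H]2CCC[C@H]1CN(C(=O)c1cc3sc(Br)cc3n1Cc1ccc(OC)cc1)C2`: > 100000 nM

Both entries are limits of the assay, not numbers. In an ADME assay on HEK-293T cells (Homo sapiens) for cytotoxicity, read by luminescence and CellTiter-Glo, with a stated time of 24 h (on this read-out lower numbers stand for higher toxicity in this test and higher numbers for lower toxicity in this test), compound 2 gives > 100000 nM, which is a limit. The data so far amount to the limit of > 100000 nM in this assay, at which 2 of the 2 values shown sit, so neither compound has a measured cytotoxic concentration.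

The next compound is compound 3 `CCCNC(=O)[C@H]1[C@@H]2CCC[C@H]1CN(C(=O)c1cc3sc(Br)cc3n1Cc1ccc(OC)cc1)C2`. The change from compound 2 is small: the two compounds have the same atoms and bonds and differ only in configuration as drawn: 1 of 3 stereo elements differ; a stereocentre at a saturated ring carbon is drawn r in compound 2 and s in compound 3. For the measured compounds named here, no measured pair shows what such a change does in this assay, so the expectation rests on the limit that compound 2 reaches, > 100000 nM. No change beyond the scatter is expected, and the estimated step is a number no higher from compound 2 to compound 3 (the limit leaves the size open). Compound 3 will most likely be reported as a limit too. Compound 3 is estimated at 100000 nM, with an expected range of 50000 nM to 200000 nM.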

Compound 3, half-maximal cytotoxic concentration: > 100000 nM
Compound 3: a limit, no number; the forecaster's own chance of this, stated with the estimate: 85%; the middle value sits exactly at the limit.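

For the compounds shown here, compound 2 and compound 3 both give only a limit, not a number, so no step between them can be read. All the results shown stop at the same point: the limit of > 100000 nM in this assay, at which 3 of the 3 values shown sit.

The compounds shown leave open whether this mirror change alters cytotoxicity, and at what concentration any of them would harm these cells.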